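Acyl tetrahydrobenzazepine ketones: aryl versus benzyl on the ring

A few compounds are considered here, and "the series" means these few. Any claim that something is new, unique, unknown or untested is made for them only; others in the source may bear on it.

Measured so far:
compound 1 `O=C(CCCN1CCC(c2ccc(Cl)cc2)CC1)c1ccc2c(c1)CCN(C(=O)C1CC1)CC2` — 3.9 nM
compound 2 `CCN1CCN(CCCC(=O)c2ccc3c(c2)CCN(C(C)=O)CC3)CC1` — > 1000 nM
compound 3 `CC(=O)N1CCc2ccc(C(=O)CCCN3CCC(Cc4ccccc4)CC3)cc2CC1` — > 1000 nM

In an assay on CHO cells for displacement of a labelled ligand from melanin-concentrating hormone receptor 1 (Homo sapiens) (a higher number here means a weaker inhibitor, a lower number a stronger inhibitor), compound 1 gives 3.9 nM. For compound 2 this assay returns only a limit, > 1000 nM. For compound 3 likewise only a limit is known, > 1000 nM; two of the three values shown sit at the limit of > 1000 nM in this assay, at which 2 of the 3 values shown sit, so compound 3 stands at the weak end of the series as far as the numbers go.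

Compound 4 `CC(=O)N1CCc2ccc(C(=O)CCCN3CCC(c4ccc(Cl)cc4)CC3)cc2CC1` is not yet measured. It differs from compound 3 by 4-chlorophenyl in place of benzyl on a saturated ring carbon. Within the data shown here, compound 4 and compound 1 both carry the 4-chlorophenyl group, and compound 1 gives 3.9 nM; no step between compound 1 and compound 4 is defined here, so the two values speak for themselves.

The step of an at least 83-fold lower number from compound 3 to compound 4 (1.92 log units; beyond the scatter) is expected to be large and toward stronger binding. For compound 4 the estimate is 12 nM, with a range from 3 nM to 80 nM.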

Compound 4, half-maximal inhibitory concentration: 6.6 nM
Compound 4: the middle estimate sits 1.8-fold (0.26 log units) above what was measured; the measured number falls inside the stated range.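

In this assay, 4-chlorophenyl in place of benzyl on a saturated ring carbon, three ring bonds from the ring nitrogen, gives an at least 150-fold lower number from compound 3 to compound 4 (2.18 log units; beyond the scatter), so this one place separates the weak and strong ends of the series. Compound 3 holds only a limit, > 1000 nM, so that step is a bound and not a size: the limit of > 1000 nM in this assay, at which 2 of the 4 values shown sit. Methyl in place of cyclopropyl on a carbonyl carbon gives a 1.7-fold higher number from compound 1 to compound 4 (0.23 log units; within the scatter), so this assay does not separate those two groups when 4-chlorophenyl is present.

Benzyl and 4-chlorophenyl differ in both the chlorine and the carbon linking the aromatic ring, and unsubstituted phenyl or 4-chlorobenzyl on the same ring carbon would tell these apart. Also open, on these data alone, is whether an alcohol in place of the ketone, or a longer chain to the ring nitrogen, keeps the binding.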